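Fluoro to chloro on an aromatic carbon

The source may hold more compounds than are shown below. What is called first, only, known or untested is meant among the compounds shown, and "the series" means these compounds.

Compound 1 (`COc1cccc(-c2cc(=O)c3ccc(C)nc3[nH]2)c1`): 72400 nM
Compound 2 (`Cc1cnc2[nH]c(-c3cccc(F)c3)cc(=O)c2c1`): 72400 nM

In a functional assay on NCI60 cells (Homo sapiens) for cytotoxicity (on this read-out higher numbers stand for weaker inhibition of growth and lower numbers for stronger inhibition of growth), compound 2 gives 72400 nM and stands level with compound 1 within the scatter. Compound 3 (`Cc1cnc2[nH]c(-c3cccc(Cl)c3)cc(=O)c2c1`) has not yet been measured. It carries chloro in place of fluoro on an aromatic carbon. Going by the values given here, no measured pair differing in one place shows how large such a change can be, so no step beyond the scatter is expected in this assay in either direction. The expected size is a 1.1-fold lower number from compound 2 to compound 3 (0.05 log units; within the scatter) and lies within the scatter. Compound 3 is estimated at 65000 nM (range 35000 nM to 100000 nM).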

Compound 3, concentration for total growth inhibition: 72400 nM
The estimate for compound 3 lay 1.1-fold (0.05 log units) below the measured number, and the stated range covers the measured number.
By their numbers in this assay, from the lowest: compounds 1, 2 and 3 (each within the scatter of the next).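

In this assay the exchange of chloro for fluoro on an aromatic carbon, meta to a large group, gives no change at the digits printed from compound 2 to compound 3 (within the scatter) and so provides the only step read at this position among the compounds shown. At this position, the two halogens cannot be told apart on this read-out. Nothing available offers an explanation for this result.

As far as these compounds go, what an amine or a carboxylic acid on this aromatic carbon would do remains open. So does whether any group here can move the number beyond the scatter.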